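The compounds below may be only part of what the source reports. "The series", "measured", "known", "first", "only" and "open" are said of these compounds alone.

Working notes on the chloropurine benzyl series.

Of the compounds shown here, three have numbers so far in a functional assay on NCI/ADR-RES cells (Homo sapiens) for cytotoxicity, read by sulforhodamine B assay, with a stated time of 48 h; on this read-out higher numbers stand for weaker inhibition of growth and lower numbers for stronger inhibition of growth. Compound 1 `ClCc1ccc(Cn2cnc3c(Cl)ncnc32)cc1` gives 5490 nM. Compound 2 `ClCc1ccc(Cn2cnc3ncnc(Cl)c32)cc1` gives 4670 nM. Compound 3 `ClCc1cccc(Cn2cnc3ncnc(Cl)c32)c1` gives 9770 nM. On these three numbers compound 2 carries the lowest value; its gap to compound 1 lies within the scatter, so no order between compound 2 and compound 1 can be read, while its gap to compound 3 lies beyond the scatter, with compound 3 the higher of the two. No pair among these three differs in a single place, so no step between measured compounds is available to lean on.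

Compound 4 `ClCc1ccc(Cn2cnc3nc(Cl)nc(Cl)c32)cc1` has not been measured in this assay. Relative to compound 2 the change is chloro in place of hydrogen on an aromatic carbon, the new chloro sitting on the core of compound 2 between two ring nitrogen atoms, meta to the chloro group already present. Among the compounds with values here, with no comparable step in hand, the expectation rests on compound 2 alone, at 4670 nM. The step from compound 2 to compound 4 is expected to be small, most likely within the scatter, leaning if anything toward a lower number, as a 1.3-fold lower number from compound 2 to compound 4 (0.13 log units; within the scatter) expresses. Compound 4 is therefore estimated at 3500 nM, within a range of 1200 nM to 10000 nM, in this assay.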

Compound 4, concentration for total growth inhibition: 4460 nM
Compound 4: middle estimate off by 1.3-fold (0.11 log units), on the low side; measured number inside the range.
By their numbers in this assay, from the lowest: compounds 4, 2, 1 and 3 (each within the scatter of the next, the first and the last beyond it).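

In this assay, within the data shown here, the only single-place step in hand is a 1.0-fold lower number from compound 2 to compound 4 (0.02 log units; within the scatter), for chloro in place of hydrogen on an aromatic carbon of the core, between two ring nitrogen atoms and meta to a chloro group. Among these compounds, this is the first reading at this position: compounds 1, 2 and 3 differ from one another in more than one place and could say nothing about it, whereas compound 2 and compound 4 now show that this hydrogen can give way to chloro with no readable change on this read-out. Nothing measured here bears on why the step stays within the scatter.

As far as these compounds go, a single substituent at a single position remains the whole basis, so it stays open whether an amine, a methoxy group or a longer chain in the same place would also leave the number within the scatter of compound 2. From the compounds shown here alone, it also stays open whether chloro at this position would give a similarly small step on the core of compound 1 or of compound 3, or in any assay other than this assay.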